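The compounds below may be only part of what the source reports. "The series", "measured", "known", "first", "only" and "open" are said of these compounds alone.

Measured so far in a physicochemical assay for lipophilicity, read by HPLC, measured as chromatographic lipophilicity, at pH 7.4; on this read-out higher numbers stand for higher lipophilicity and lower numbers for lower lipophilicity
Compound 1 `O=C(C1CCN(c2ncccn2)CC1)N1N=CC[C@H]1c1ccccc1` - 4.7
Compound 2 `O=C(c1cscn1)N1CCC(C(=O)N2N=CC[C@H]2c2ccccc2)CC1` - 3

Of these two compounds, compound 2 stands lowest at 3, clearly under compound 1 at 4.7. The next compound, compound 3 `CC(=O)N1CCC(C(=O)N2N=CC[C@H]2c2ccccc2)CC1`, has not yet been measured. It differs from compound 2 in one place: methyl in place of 1,3-thiazol-4-yl on a carbonyl carbon. In words, this is methyl in place of 1,3-thiazol-4-yl on a carbonyl carbon, so that (1,3-thiazol-4-yl)carbonyl becomes acetyl.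

Going by the values given here, only one measured step bears on this change, and only indirectly: a number 1.70 log units lower from compound 1 to compound 2 (beyond the scatter). That large step, beyond the scatter, brought in the (1,3-thiazol-4-yl)carbonyl group in place of pyrimidin-2-yl on an amine nitrogen in a ring. Among the compounds with values here, no measured pair isolates the swap at hand, so its size remains a judgement. The entering group is far smaller than the one leaving, and a further fall in this assay is expected, smaller than that earlier step but still beyond the scatter. The expected move is a number 0.70 log units lower from compound 2 to compound 3 (beyond the scatter). Compound 3 is therefore estimated at 2.3, within a range of 1.9 to 2.8.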

Compound 3, distribution coefficient: 2.5
For compound 3 the middle estimate is 0.20 log units below the measured one; measured number inside the range.
By their numbers in this assay, from the lowest: compound 3; then compound 2; then compound 1.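

In this assay, the carbonyl-bearing group on the ring nitrogen now has a second example, and the group on that carbonyl carbon still moves the read-out, with a number 0.50 log units lower from compound 2 to compound 3 (beyond the scatter) when 1,3-thiazol-4-yl, with its 5 heavy atoms and one aromatic ring, gives way to methyl, with 1 heavy atom and no ring. Set against a number 2.20 log units lower from compound 1 to compound 3 (beyond the scatter), this modest step shows that the change at the carbonyl carbon is smaller than either step away from the pyrimidin-2-yl compound, and both compounds with a carbonyl at this nitrogen stand lower than compound 1. No measurement given here accounts for these differences. This single swap changes the ring and the atom count together, so it leaves open which of the two goes with the lower number; a cyclopropyl or a longer chain such as propyl on the same carbonyl carbon would help to separate them. Going by these compounds, whether an amine or a carboxylic acid at that place would extend the fall seen with acetyl, or reverse it, also remains open.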